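The source may report more compounds than this note shows. Statements on the series, on what has been measured and on what is new or still open speak of the compounds shown alone.

Measured in a functional assay on HT-29 cells (Homo sapiens) for antiproliferative activity, read by sulforhodamine B assay, with a stated time of 48 h; a lower number here means a stronger inhibitor, a higher number a weaker inhibitor:

- compound 1 `O=C1NCCN1c1ccc(S(=O)(=O)Nc2ccc(I)cc2)cc1` gives 650 nM
- compound 2 `O=C1NCCN1c1ccc(S(=O)(=O)Nc2ccccc2)cc1` gives 280 nM
- compound 3 `Cc1cc(C)cc(NS(=O)(=O)c2ccc(N3CCNC3=O)cc2)c1` gives 82 nM

Among these three, compound 3 has the lowest number and is the most potent, with both of the others beyond the scatter from it. The next compound to be tested is compound 4 `O=C1NCCN1c1ccc(S(=O)(=O)Nc2ccc(Cl)cc2)cc1`, which has 4-chlorophenyl in place of 3,5-dimethylphenyl on a sulfonamide nitrogen.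

Two measured steps show what happens when 3,5-dimethylphenyl enters: a 3.4-fold lower number from compound 2 to compound 3 (0.53 log units; beyond the scatter) and a 7.9-fold lower number from compound 1 to compound 3 (0.90 log units; beyond the scatter). Compound 4 gives that group up, so these steps, read in reverse, point to a higher number. A third step compares iodo with hydrogen on the same framework: a 2.3-fold lower number from compound 1 to compound 2 (0.37 log units; beyond the scatter). Going by the values given here, it offers no sign that a group in that place restores the lost potency, although iodo is not chloro, and no chloro compound has been measured yet. Compound 4 is therefore expected to land near compound 1 and compound 2, a modest step upward. The expected change is a 5.5-fold higher number from compound 3 to compound 4 (0.74 log units; beyond the scatter). For compound 4 the estimated value is 450 nM, with an expected range from 170 nM to 1100 nM.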

Compound 4, half-maximal inhibitory concentration: 220 nM
The estimate for compound 4 lay 2.0-fold (0.31 log units) above the measured number, and the stated range covers the measured number.
By their numbers in this assay, from the lowest: compound 3; then compounds 4 and 2 (each within the scatter of the next); then compound 1.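

On the sulfonamide nitrogen, 4-chlorophenyl does not match 3,5-dimethylphenyl in this assay: the change gives a 2.7-fold higher number from compound 3 to compound 4 (0.43 log units; beyond the scatter) and leaves compound 3 with the lowest number of the four. Chloro also differs little from a bare hydrogen on this ring, since a 1.3-fold lower number from compound 2 to compound 4 (0.10 log units; within the scatter) stays within the scatter, yet it does differ from iodo, with a 3.0-fold lower number from compound 1 to compound 4 (0.47 log units; beyond the scatter) showing that the two halogens cannot be treated as interchangeable on this framework. Nothing measured here explains these differences, so the numbers describe what happens at this position without saying why.

The four compounds leave open whether the lower number of compound 3 needs both methyl groups of 3,5-dimethylphenyl, or whether one methyl group on the ring would give much the same result. They also leave open how a fluoro or a methoxy group would compare with the chloro of 4-chlorophenyl, and whether an amine or a carboxylic acid on this ring would be tolerated at all in this assay.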